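The compounds below may be only part of what the source reports. "The series", "measured", "known", "first", "only" and "open" are said of these compounds alone.

Among the compounds with values here, compound 3 `Cc1cc(NC(=O)Cn2nnc(-c3cccc(Cl)c3)n2)n(C2CCCCC2)n1` is the one member of this small set for which a number exists in an assay on HEK293 cells for activation of Kir3.1/Kir3.2 (Homo sapiens), read by thallium flux; a lower number here means a smaller maximal response, a higher number a larger maximal response; in that assay compound 3 reaches 89%. Within the data shown here, compound 1 `O=C(Cn1nnc(-c2ccccc2)n1)Nc1cc(C2(C(F)(F)F)CC2)nn1C1CCCCC1` and compound 2 `O=C(Cn1nnc(-c2ccccc2)n1)Nc1ccccn1` carry a related amide arm on other cores, and in this assay compound 1 is reported as "not active" (no number reported), while compound 2 is reported as "not active" (no number reported); neither gives a number, so no step between two measured compounds can be counted. Compound 4 `Cc1cc(NC(=O)Cn2nnc(-c3ccccc3F)n2)n(C2CCCCC2)n1` keeps the core of compound 3 and changes only the ring that sits on the five-membered aromatic ring with 4 nitrogen: 2-fluorophenyl in place of 3-chlorophenyl on an aromatic carbon. Nothing measured shows how this part of the molecule is tolerated, since the two compounds without a number differ from compound 3 in more than that ring. A step of some size is therefore plausible in either direction, and a loss beyond the scatter is thought more likely than a gain, as compound 3 already reaches 89%. Compound 4 is expected to give about 60% in this assay, within 15% to 95%. The expected step is then a number 29 percentage points lower from compound 3 to compound 4 (beyond the scatter).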

Compound 4, largest response reached (Emax), in percent of the reference or control that the assay uses: 88%
Estimate against measurement, compound 4: 28 percentage points below, within the range that was stated.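

In this assay, the step on replacing 3-chlorophenyl with 2-fluorophenyl on an aromatic carbon of the five-membered aromatic ring with 4 nitrogen is a number 1 percentage points lower from compound 3 to compound 4 (within the scatter). Within the data shown here, with the core of compound 3 held fixed, this gives the first reading at this position: the response survives a change in both the halogen and its place on the phenyl ring, something compound 1 and compound 2 could not show, as they differ from compound 3 in more than one place and their steps cannot be read. No measurement given here bears on why the two aryl groups give this result.

On these data alone, both groups compared are halogen-bearing phenyl rings, so it remains open whether the position would also accept a phenyl ring carrying an amine or a carboxylic acid, or a longer alkyl chain in place of the ring. As far as these compounds go, it also remains open whether the "not active" reports for compound 1 and compound 2 trace to their cores, to their unsubstituted phenyl ring, or to both.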